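Returning an Aromatic Ring to the Core of Compound 2

The source may report more compounds than this note shows. Statements on the series, on what has been measured and on what is new or still open speak of the compounds shown alone.

Compound 2 `CCC(CC)c1ccc2c(NCCCNCc3cccc(OC)c3O)ccnc2c1` stands level with compound 3 `CCC(CC)c1ccc2c(NCCCNCc3ccco3)ccnc2c1` at the bottom of the three measured numbers. In an ADME assay for permeability, using PAMPA, with a stated time of 30 min, at pH 7.4 (on this read-out lower numbers stand for lower permeability and higher numbers for higher permeability), compound 2 gives 23 10^-6 cm/s, compound 3 gives 23 10^-6 cm/s, and no change at the digits printed from compound 2 to compound 3 (within the scatter). Compound 1 `Fc1ccc(Oc2ccc3c(NCCCNCc4ccco4)ccnc3c2)cc1` gives 317 10^-6 cm/s, and a 14-fold lower number from compound 1 to compound 3 (1.14 log units; beyond the scatter). Compound 4 `COc1cccc(CNCCCNc2ccnc3cc(-c4ccc(C(C)(C)C)cc4)ccc23)c1O` carries 4-(tert-butyl)phenyl in place of pentan-3-yl on an aromatic carbon. Within the data shown here, the only measured step that bears on this change is the one from compound 1 to compound 3, which runs the other way, from 4-fluorophenoxy to pentan-3-yl; the change toward compound 4 puts a six-membered aromatic ring back on the same carbon, though a different one, 4-(tert-butyl)phenyl. Compound 4 is therefore expected to rise in this assay, by a 4.3-fold higher number from compound 2 to compound 4 (0.64 log units; beyond the scatter). Compound 4 is estimated at 100 10^-6 cm/s, with a range from 30 10^-6 cm/s to 320 10^-6 cm/s.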

Compound 4, apparent permeability: 237 10^-6 cm/s
Beside the measured number, compound 4's estimate is 2.4-fold (0.37 log units) below it, and the stated range covers the measured number.
By their numbers in this assay, from the lowest: compounds 2 and 3 (each within the scatter of the next); then compounds 4 and 1 (each within the scatter of the next).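

With the 2-hydroxy-3-methoxyphenyl group held constant, the result in this assay is a 10-fold higher number from compound 2 to compound 4 (1.01 log units; beyond the scatter), for 4-(tert-butyl)phenyl in place of pentan-3-yl on the aromatic carbon. The earlier large step at this position came only from compounds carrying furan-2-yl, so pentan-3-yl now gives the lower number in both measured pairs, and neither pair goes against this. Nothing shown here explains the step.

The compounds shown leave open whether an unsubstituted phenyl or a morpholine on this carbon would give a similar number. They also leave open whether furan-2-yl would match 2-hydroxy-3-methoxyphenyl with 4-(tert-butyl)phenyl present.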